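Two inverted ring stereocentres on the aminomethyl iminosugar

This account rests on a few compounds, and the source may have more. Where it says the series, first, only, none or still open, it means among the compounds named here.

Compound 1 `O=C(/C=C/c1ccc(C(F)(F)F)cc1)NC[C@H]1NC[C@H](O)[C@@H](O)[C@H]1O` carries the trifluoromethyl cinnamamide on the aminomethyl group and gives 41% in an assay on isolated protein for inhibition of alpha-galactosidase (Coffea arabica), read by spectrophotometry, tested at 100 uM; on this read-out higher numbers stand for more inhibition at the one concentration tested (going by the name of the read-out) and lower numbers for less inhibition. The free amines are weaker on this read-out: compound 2 `NC[C@@H]1NC[C@H](O)[C@H](O)[C@H]1O` gives 13% and compound 3 `NC[C@@H]1NC[C@H](O)[C@@H](O)[C@H]1O` gives 9%. Compound 3 thus sits at the low end of the three numbers shown, separated from compound 1 by a gap beyond the scatter, while its gap to compound 2 lies within the scatter.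

Within the data shown here, the only measured step between configurational isomers is a number 4 percentage points lower from compound 2 to compound 3 (within the scatter); that step is attributed to the fact that compounds 2 and 3 differ only in the configuration as drawn and it shows no change beyond the scatter for a single inverted ring stereocentre.

Compound 4 `NC[C@H]1NC[C@H](O)[C@H](O)[C@H]1O` is not yet measured. It differs from compound 3 as the two compounds have the same atoms and bonds and differ only in configuration as drawn: 2 of 4 stereo elements differ; a stereocentre at a saturated ring carbon is drawn S in compound 3 and R in compound 4; a stereocentre at a saturated ring carbon is drawn R in compound 3 and S in compound 4. Two stereocentres change here rather than one, so the measured step is only a partial guide, but it points to a small effect. The expected step is therefore a number 3 percentage points higher from compound 3 to compound 4 (within the scatter), with no direction beyond the scatter anticipated. The estimate for compound 4 in this assay is 12%, with a range from 2% to 26%.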

Compound 4, a percentage reported as inhibition, at one concentration (the size of the read-out at that concentration, not a potency): "not active" (no number reported)
The entry for compound 4 holds no number; no gap can be computed for the estimate.
By their numbers in this assay, from the lowest: compounds 3 and 2 (each within the scatter of the next); then compound 1.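

In this assay, among these compounds, compound 4 is recorded as not active, with no number, so no step from compound 2 or compound 3 to compound 4 can be read. The compounds shown leave open whether the two inverted ring stereocentres separating compound 3 from compound 4 change inhibition beyond the scatter.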